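The source may hold more compounds than are shown below. What is called first, only, known or untested is meant among the compounds shown, and "the series" means these compounds.

Measured compounds in an assay on isolated protein with malate dehydrogenase, mitochondrial (Sus scrofa) as the target; on this read-out higher numbers stand for weaker inhibition and lower numbers for stronger inhibition:

- compound 1 `O=C(O)c1cnc2cc(OCCOc3ccccc3)ccc2c1O` — 60300 nM
- compound 2 `O=C(O)c1cnc2cc(S(=O)(=O)O)ccc2c1O` — 2140000 nM
- compound 3 `O=C(O)c1cnc2cc(OCCOc3ccc(F)cc3)ccc2c1O` — 18200 nM

Compound 2, carrying the sulfo group, stands at the top of the three numbers in this assay; compound 1 is the nearest to it and compound 3 the furthest, both well beyond the scatter. For the measured compounds named here, the only single-point step among the measured compounds is a 3.3-fold lower number from compound 1 to compound 3 (0.52 log units; beyond the scatter), which concerns the distal aromatic ring and not the position varied here.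

Compound 4 `O=C(O)c1cnc2cc(O)ccc2c1O` is not yet measured. The change from compound 2 is hydroxy in place of sulfo on an aromatic carbon. Going by the values given here, no measured step bears directly on it; what is known is that the sulfo compound 2 gives a far higher number than compounds 1 and 3, which carry an ether chain at the same position. A hydroxy group at this position is therefore expected to give a number lower than compound 2, though with wide uncertainty, expected as an 8.6-fold lower number from compound 2 to compound 4 (0.93 log units; beyond the scatter). Compound 4 is estimated at 250000 nM in this assay, within 40000 nM to 1500000 nM.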

Compound 4, half-maximal inhibitory concentration: 490000 nM
The estimate for compound 4 lay 2.0-fold (0.29 log units) below the measured number; measured number inside the range.
By their numbers in this assay, from the lowest: compound 3; then compound 1; then compound 4; then compound 2.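

Hydroxy in place of sulfo on an aromatic carbon gives, in this assay, a 4.4-fold lower number from compound 2 to compound 4 (0.64 log units; beyond the scatter), the first measured change at this position that leaves only a single heavy atom there. Taking away the sulfo group closes only part of the gap to the ether chain: compound 4 gives 490000 nM and compound 1 gives 60300 nM, so the number of compound 4 remains the higher of the two and a hydroxy group alone does not reach the level of that chain. No measured information available here explains either difference.

Going by these compounds, it remains open whether the lower number of compound 1 needs the whole chain with its terminal aromatic ring or only part of it. A methoxy group, a shorter or longer ether chain, an amine or a carboxylic acid at this position would help to separate these possibilities.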